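Swapping a Methyl for a Fluorine on the Pendant Ring

The source may hold more compounds than are shown below. What is called first, only, known or untested is meant among the compounds shown, and "the series" means these compounds.

Compound 1 `C=CCn1c(=O)/c(=C\c2ccccc2Cl)[nH]c(=O)/c1=C\c1ccccc1OC`: 5300 nM
Compound 2 `C=CCn1c(=O)/c(=C\c2ccc(C)cc2)[nH]c(=O)/c1=C\c1ccccc1OC`: "not active" (no number reported)

In a functional assay on A549 cells (Homo sapiens) for cytotoxicity, read by CCK-8 assay, with a stated time of 72 h (on this read-out higher numbers stand for weaker inhibition and lower numbers for stronger inhibition), compound 1 gives 5300 nM, a weak result. In this assay compound 2 gives "not active" (no number reported), so no number stands for it and its place on the scale cannot be fixed. Compound 3 `C=CCn1c(=O)/c(=C\c2ccccc2F)[nH]c(=O)/c1=C\c1ccccc1OC` differs from compound 2 by 2-fluorophenyl in place of 4-methylphenyl on a double-bonded chain carbon bound to an aromatic carbon. Going by the values given here, no measured step covers this change, so its size and direction are unknown. Compound 1, which carries a 2-chlorophenyl, gives 5300 nM, and compound 3 may come out near that weak level. For compound 3 in this assay the expected value is 9000 nM, estimated between 3000 nM and 40000 nM, with a fair chance that again no activity is reported.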

Compound 3, half-maximal inhibitory concentration: "not active" (no number reported)
No number was reported for compound 3; there is nothing to compare the estimate with.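

Going by these compounds alone, compound 2 and compound 3 both come back from this assay without a number, so no step from one to the other can be read. The compounds shown leave open how much the pendant ring group matters to activity. Nothing measured here bears on this result.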